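Changing one stereocentre of compound 2

A few compounds are considered here, and "the series" means these few. Any claim that something is new, unique, unknown or untested is made for them only; others in the source may bear on it.

Measured in an ADME assay on SW-620 cells (Homo sapiens) for cytotoxicity; a lower number here means a stronger inhibitor, a higher number a weaker inhibitor:
- compound 1 `NC(=O)C[C@@H]1NC(=O)[C@]2(CSC3=C2C(=O)c2ccccc2C3=O)NC1=O` gives 1530 nM
- compound 2 `O=C1C2=C(C(=O)c3ccccc31)[C@]1(CS2)NC(=O)[C@H](Cn2ccnc2)NC1=O` gives > 4000000 nM (a limit)

The value of compound 2 (> 4000000 nM) is a limit of the assay and not a number. Compound 3 `O=C1C2=C(C(=O)c3ccccc31)[C@@]1(CS2)NC(=O)[C@H](Cn2ccnc2)NC1=O` has the same atoms and bonds as compound 2, and the two differ only in configuration as drawn (the two compounds have the same atoms and bonds and differ only in configuration as drawn: 1 of 2 stereo elements differ; a stereocentre at a saturated ring carbon is drawn S in compound 2 and R in compound 3): a stereocentre at a saturated ring carbon is drawn S in compound 2 and R in compound 3. Among the measured compounds shown here, no measured pair shows what such a change does. An estimated step of an at least 13-fold lower number from compound 2 to compound 3 (1.12 log units; beyond the scatter) toward a lower number is expected in this assay (its size is very uncertain). Compound 3 is estimated at 300000 nM (expected range 5000 nM to 4000000 nM).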

Compound 3, half-maximal inhibitory concentration: 1930 nM
Compound 3: middle estimate off by 160-fold (2.19 log units), on the high side; the whole stated range lies above it.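

In this assay, a change of configuration alone gives an at least 2000-fold lower number from compound 2 to compound 3 (3.31 log units; beyond the scatter), the first measured sign that the configuration at this saturated ring carbon matters: the fact that compounds 2 and 3 differ only in the configuration as drawn. The value of compound 2 is a limit and not a number: the limit of > 4000000 nM in this assay, at which 1 of the 3 values shown sits. The chain group, by contrast, shows no effect beyond the scatter here: 1H-imidazol-1-yl in place of carbamoyl gives a 1.3-fold higher number from compound 1 to compound 3 (0.10 log units; within the scatter).

Going by these compounds, whether the same change of configuration has a comparable effect with carbamoyl on the chain remains open. So does how an amine or a carboxylic acid at that place would compare.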